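Acetoxymethyl to hydroxymethyl from compound 2

The compounds below may be only part of what the source reports. "The series", "measured", "known", "first", "only" and "open" are said of these compounds alone.

In a functional assay on A549 cells (Homo sapiens) for antiproliferative activity, read by MTT assay, with a stated time of 48 h (on this read-out lower numbers stand for stronger inhibition and higher numbers for weaker inhibition), compound 1 `CC(=O)OC/C1=C/C[C@](C)(CCC=C(C)C)/C=C/[C@@H](OC(=O)C=C(C)C)[C@](C)(O)/C=C/C1=O` gives 2950 nM and compound 2 `CC(=O)OC/C1=C/C[C@](C)(CCC=C(C)C)/C=C/[C@@H](OC(=O)C=C(C)C)[C@](C)(OC(C)=O)/C=C/C1=O` gives 15100 nM, the higher of the two numbers. Compound 3 `CC(=O)O[C@]1(C)/C=C/C(=O)/C(CO)=C\C[C@](C)(CCC=C(C)C)/C=C/[C@H]1OC(=O)C=C(C)C` differs from compound 2 by hydrogen in place of acetyl on an oxygen on a saturated carbon: hydrogen in place of acetyl, acetoxymethyl to hydroxymethyl. For the measured compounds named here, the only measured step, a 5.1-fold higher number from compound 1 to compound 2 (0.71 log units; beyond the scatter), put an acetyl on a different oxygen, so it bears only indirectly. A change toward a lower number is expected here, smaller in size than that step. The estimated step is a 2.3-fold lower number from compound 2 to compound 3 (0.37 log units; beyond the scatter). Compound 3 is expected at 6500 nM, with a range of 2500 nM to 18000 nM.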

Compound 3, half-maximal inhibitory concentration: 3150 nM
Estimate against measurement, compound 3: 2.1-fold (0.31 log units) above, and the stated range covers the measured number.
By their numbers in this assay, from the lowest: compounds 1 and 3 (each within the scatter of the next); then compound 2.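

In this assay, the acetoxymethyl position is also sensitive to loss of its acetyl, with hydrogen in place of acetyl giving a 4.8-fold lower number from compound 2 to compound 3 (0.68 log units; beyond the scatter). Compound 2 had previously been reached only through acetylation of the other oxygen, a 5.1-fold higher number from compound 1 to compound 2 (0.71 log units; beyond the scatter), so it now carries the higher number in both single-place comparisons. Nothing available explains this step.

Open, going by these compounds, is whether a propionyl ester or a methyl ether on this oxygen would track with the acetyl or with the hydrogen. On these data alone, the effect of hydrogen on both oxygens also remains open.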